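This account rests on a few compounds, and the source may have more. Where it says the series, first, only, none or still open, it means among the compounds named here.

Compound 1, `COc1ccc(-c2csc3nc(-c4cc(F)c(Cl)cc4Cl)nn23)cc1`, was tested in a functional assay on the whole organism (strain Wister albino) for inhibition, with Rattus norvegicus as the target, read by paw edema, with stated times of 30 min and 3 h, at a dose of 50 mg/kg by the oral route (a higher number here means more inhibition at the dose given (going by the name of the read-out), a lower number less inhibition), where compound 1 gives 40.6%. Compound 2, `Fc1ccc(-c2csc3nc(-c4cc(F)c(Cl)cc4Cl)nn23)cc1`, in this assay gives 48.8%. Going by the values given here, the one measured step between them, fluoro in place of methoxy on an aromatic carbon, shows a number 8.2 percentage points higher from compound 1 to compound 2 (within the scatter). Among these two numbers compound 1 stands lowest, but its only neighbour, compound 2, lies within the scatter of it, so no order between the two can be claimed.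

The unmeasured compound 3, `Fc1cc(-c2nc3scc(-c4ccc(Cl)cc4Cl)n3n2)c(Cl)cc1Cl`, differs from compound 1 as follows: 2,4-dichlorophenyl in place of 4-methoxyphenyl on an aromatic carbon. The step from compound 1 to compound 2 bears on this change only loosely: it also exchanges the group on an aromatic carbon of the shared core, and it stayed within the scatter. Among the compounds with values here, no measured step brings in 2,4-dichlorophenyl, so the direction of the change is open. The expectation for compound 3 is therefore a step of a number 4.4 percentage points higher from compound 1 to compound 3 (within the scatter) in this assay, not beyond the scatter. The estimate for compound 3 in this assay is 45%, with a range from 30% to 60%.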

Compound 3, a percentage reported as inhibition, in the whole organism at one dose (the size of the read-out at that dose, not a potency): 17.2%
The estimate for compound 3 lay 27.8 percentage points above the measured number; measured number outside the range, below it.
By their numbers in this assay, from the lowest: compound 3; then compounds 1 and 2 (each within the scatter of the next).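

At this position, on an aromatic carbon of a five-membered aromatic ring with 1 nitrogen and 1 sulfur, the earlier pair had shown no change that could be told from the scatter, but the group here is now seen to matter in this assay. Placing 2,4-dichlorophenyl there in place of 4-methoxyphenyl gives a number 23.4 percentage points lower from compound 1 to compound 3 (beyond the scatter), and placing it there in place of 4-fluorophenyl gives a number 31.6 percentage points lower from compound 2 to compound 3 (beyond the scatter). The 2,4-dichlorophenyl and 4-methoxyphenyl groups have the same count of heavy atoms, so the first of these steps comes without a change in that count, and nothing available explains either step.

The compounds shown do not separate the two chlorines of the entering group, so a 4-chlorophenyl or a 2-chlorophenyl group at this position could fall on either side of these numbers. Going by these compounds, how an amine or a carboxylic acid on the phenyl ring would read here remains open, as does whether this loss of inhibition at one oral dose would hold at other doses.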